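Trading a Methoxy Group for Hydrogen in Two Matched Pairs

This account rests on a few compounds, and the source may have more. Where it says the series, first, only, none or still open, it means among the compounds named here.

Three compounds have so far been measured in a functional assay on HCT-15 cells (Homo sapiens) for cytotoxicity, read by MTT assay, with a stated time of 72 h; on this read-out lower numbers stand for stronger inhibition and higher numbers for weaker inhibition:

Compound 1, `COc1cc(OC)c(OC)cc1/C=C/C(=O)c1ccccc1F`, gives 55.3 nM.
Compound 2, `COc1ccc(OC)c(/C=C/C(=O)c2ccccc2F)c1`, gives 61.1 nM.
Compound 3, `COc1ccc(C(=O)/C=C/c2ccc(OC)c(OC)c2OC)c(F)c1`, gives 31.7 nM.

Compound 1 and compound 2 share a core and differ in one place, (hydrogen in place of methoxy on an aromatic carbon). That step gave a 1.1-fold higher number from compound 1 to compound 2 (0.04 log units; within the scatter), so the two numbers cannot be told apart on this read-out. Compound 3 is built on a different core; how the two cores differ is not broken down here, and its number sits within the scatter of both compound 1 and compound 2.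

The unmeasured compound 4, `COc1ccc(C(=O)/C=C/c2ccc(OC)cc2OC)c(F)c1`, stands to compound 3 as compound 2 stands to compound 1: the difference is hydrogen in place of methoxy on an aromatic carbon. It is the same kind of change, not the same change, since the surroundings differ. In the first pair the carbon is ortho to a methoxy group, meta to a methoxy group and para to a large group; in the second it is ortho to two methoxy groups and meta to a large group.

The step from compound 3 to compound 4 in this assay is expected to be small, a 1.3-fold higher number from compound 3 to compound 4 (0.12 log units; within the scatter), because the matching change gave a 1.1-fold higher number from compound 1 to compound 2 (0.04 log units; within the scatter). Compound 4 is therefore estimated at 42 nM, with a likely range from 18 nM to 100 nM.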

Compound 4, half-maximal inhibitory concentration: 72.2 nM
Beside the measured number, compound 4's estimate is 1.7-fold (0.24 log units) below it, within the range that was stated.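

In this assay, putting hydrogen in place of the methoxy group on the core of compound 3 gave a 2.3-fold higher number from compound 3 to compound 4 (0.36 log units; beyond the scatter), so on this core the change goes with a modest weakening that stands clear of the usual noise. Set beside the same kind of change on the core of compound 1, the result does not show that the two cores respond differently, even though the two steps look unequal on paper: the same change on two cores in this assay, a 1.1-fold higher number (0.04 log units; within the scatter) from compound 1 to compound 2 and a 2.3-fold higher number (0.36 log units; beyond the scatter) from compound 3 to compound 4, 2.1-fold (0.31 log units) apart, within the scatter of two such steps. The two pairs are therefore compatible with the change carrying over from one core to the other, but they do not prove that it does, and two pairs cannot supply a rule for other cores in this series or show whether the different surroundings of the carbon matter.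

What the compounds shown leave open is how a hydroxyl group, an ethoxy group or an amine on that same aromatic carbon would compare with methoxy and hydrogen in this assay. From the compounds shown here alone, all four compounds also carry a fluorine atom, so how this swap would behave with a chlorine atom in its place remains open too.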